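The source may hold more compounds than are shown below. What is called first, only, known or untested is meant among the compounds shown, and "the series" means these compounds.

Of the compounds shown here, two sharing one core have been measured so far. Compound 1 `COc1cc(C(=O)c2sc(-c3cc(OC)c(OC)c(OC)c3)cc2N)cc(OC)c1OC` carries a trimethoxyphenyl group on its core, and compound 2 `COc1cc(C(=O)c2sc(-c3ccsc3)cc2N)cc(OC)c1OC` carries a thiophen-3-yl group at the corresponding place. In a functional assay on L1210 cells (Mus musculus) for antiproliferative activity (on this read-out higher numbers stand for weaker inhibition and lower numbers for stronger inhibition), compound 1 gives 2300 nM, while compound 2 gives 12 nM. Compound 2 therefore holds the lower of the two numbers, and compound 1 sits far above it, well beyond the usual scatter of repeated measurements.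

Compound 3 `COc1cccc(-c2cc(N)c(C(=O)c3cc(OC)c(OC)c(OC)c3)s2)c1` has not yet been tested. It differs from compound 2 in a single place: 3-methoxyphenyl in place of thiophen-3-yl on an aromatic carbon. Among the measured compounds shown here, no measured pair shows exactly this change, so its effect cannot be read off directly; what the data show is only that the thiophen-3-yl group of compound 2 goes with a much lower number than the trimethoxyphenyl group of compound 1. The 3-methoxyphenyl group falls between those two in heavy-atom count, so a moderate rise is expected, a 3.3-fold higher number from compound 2 to compound 3 (0.52 log units; beyond the scatter). For compound 3 the expected value in this assay is 40 nM, with a likely range from 8 nM to 200 nM.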

Compound 3, half-maximal inhibitory concentration: 22 nM
Beside the measured number, compound 3's estimate is 1.8-fold (0.26 log units) above it; the measured number falls inside the stated range.
By their numbers in this assay, from the lowest: compounds 2 and 3 (each within the scatter of the next); then compound 1.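

Replacing thiophen-3-yl with 3-methoxyphenyl on this aromatic carbon, next to the ring sulfur, gives in this assay a 1.8-fold higher number from compound 2 to compound 3 (0.26 log units; within the scatter), so the two groups cannot be told apart in this measurement. The earlier pair showed only that a large difference can arise at this place. Here a five-membered aromatic ring with 5 heavy atoms and a six-membered aromatic ring of carbon only with 8 heavy atoms go with matching read-outs, and a six-membered ring alone therefore does not bring the much higher number of compound 1 at 2300 nM. No separate data are available to explain why this exchange leaves the number within the scatter.

The compounds shown do not reveal which of the methoxy groups of the trimethoxyphenyl group in compound 1 goes with its higher number, since only the 3-methoxyphenyl and trimethoxyphenyl patterns appear here. From the compounds shown here alone, it also remains open how this position would respond to a group of a different kind, such as a carboxylic acid or an amine.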